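The source may report more compounds than this note shows. Statements on the series, on what has been measured and on what is new or still open speak of the compounds shown alone.

Working notes on the series. In a functional assay on MCF7 cells (Homo sapiens) for antiproliferative activity, read by MTT assay, with a stated time of 72 h (on this read-out lower numbers stand for stronger inhibition and higher numbers for weaker inhibition), compound 1 `C=C1CN/C(=N/c2ccccc2)S1` gives only a limit, > 100000 nM, and no number. Compound 2 `COc1ccc(/C=C2\S/C(=N\c3ccccc3)N(C)C2=O)cc1` likewise reaches only a limit in this assay, > 100000 nM. Two of the three results therefore sit at the limit of > 100000 nM in this assay, at which 2 of the 3 values shown sit. Among the measured compounds shown here, compound 3 `COc1ccc(/C=C2/CN(C)/C(=N/c3ccc(F)cc3)S2)cc1` is the one member of the set with a measured number: in this assay compound 3 gives 8000 nM. For the measured compounds named here, compound 3 thus stands alone; the other two results are limits, so no ranking among the three can be drawn from them, and no step between measured compounds is available.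

Compound 4 `COc1ccc(/C=C2/CN(C)/C(=N/c3ccc(Br)cc3)S2)cc1` is not yet measured. It differs from compound 3 in one place: bromo in place of fluoro on an aromatic carbon. Going by the values given here, no measured pair shows such an exchange of one halogen for another, so no step size can be read from the data. The expectation is a step in this assay that stays within the usual scatter, or at most leans slightly toward stronger inhibition, the step from compound 3 to compound 4 being estimated at a 1.3-fold lower number from compound 3 to compound 4 (0.12 log units; within the scatter). For compound 4 the estimate in this assay is 6000 nM, with a range from 2000 nM to 18000 nM.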

Compound 4, half-maximal inhibitory concentration: 7400 nM
The estimate for compound 4 lay 1.2-fold (0.09 log units) below the measured number; the measured number falls inside the stated range.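

In this assay, bromo in place of fluoro on an aromatic carbon, para to a large group, gives a 1.1-fold lower number from compound 3 to compound 4 (0.03 log units; within the scatter). Among the compounds shown here, this is the first pair of measured compounds that differ in one place, and it shows that at this position the read-out does not distinguish the two halogens, something the single number and two limits available earlier could not show. Nothing in the data shown bears on a cause for this result.

As far as these compounds go, whether the same position accepts a group other than a halogen remains open, since an amine or a carboxylic acid on this aromatic carbon of the shared core would test the position beyond the 4-fluorophenyl to 4-bromophenyl exchange seen here. Steps to compound 1 and compound 2 cannot be read, as both results are limits and not numbers, so the parts of the core in which those two compounds differ from compound 3 and compound 4 also remain unresolved.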